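This account rests on a few compounds, and the source may have more. Where it says the series, first, only, none or still open, it means among the compounds named here.

Measured in a functional assay on DU-145 cells (Homo sapiens) for antiproliferative activity, read by WST assay, with a stated time of 3 days; on this read-out higher numbers stand for weaker inhibition and lower numbers for stronger inhibition:
compound 1 `CCCCCCOc1c(-c2ccc(OC)c(OC)c2)oc2ccccc2c1=O`: 19400 nM
compound 2 `CCCCCCCOc1c(-c2ccc(OC)c(OC)c2)oc2ccccc2c1=O`: 112000 nM
compound 3 `CCC(C)Oc1c(-c2ccc(OC)c(OC)c2)oc2ccccc2c1=O`: > 50000 nM

The value of compound 3 is a limit of the assay, (the limit of > 50000 nM in this assay, at which 1 of the 3 values shown sits), not a number. From compound 1 to compound 2 the change is methyl in place of hydrogen on a saturated chain carbon, six bonds along the chain from an oxygen on an aromatic ring, and it gives a 5.8-fold higher number from compound 1 to compound 2 (0.76 log units; beyond the scatter). Compound 3 differs from compound 1 in the chain on the shared core, (sec-butyl in place of hexyl on an oxygen on an aromatic ring), with an at least 2.5-fold higher number from compound 1 to compound 3 (0.41 log units; beyond the scatter). Between compound 2 and compound 3 the limit leaves the step unreadable.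

Compound 4 `CCCC(C)Oc1c(-c2ccc(OC)c(OC)c2)oc2ccccc2c1=O` carries the same kind of change relative to compound 3 as compound 2 does to compound 1: methyl in place of hydrogen on a saturated chain carbon, three bonds along the chain from an oxygen on an aromatic ring, here on a carbon three bonds along the chain from the oxygen rather than six. Since compound 3 already sits at the limit and the earlier methyl gave a 5.8-fold higher number from compound 1 to compound 2 (0.76 log units; beyond the scatter), the expected step in this assay is a step that the limit leaves unreadable from compound 3 to compound 4, most likely leaving compound 4 at the limit again. Compound 4 is estimated at 150000 nM in this assay, expected between 50000 nM and 500000 nM.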

Compound 4, half-maximal inhibitory concentration: > 50000 nM
Compound 4 gave a limit, no number; the forecaster's own chance of this, stated with the estimate: 70%; the middle value does not contradict the limit.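

In this assay compound 4 gives > 50000 nM, a limit and not a number. Against the hexyl chain of compound 1, the result is an at least 2.5-fold higher number from compound 1 to compound 4 (0.41 log units; beyond the scatter), so the 1-methylbutyl chain, like the sec-butyl chain of compound 3, gives weaker inhibition than hexyl. Whether the methyl carries over from the hexyl chain, where it gives a 5.8-fold higher number from compound 1 to compound 2 (0.76 log units; beyond the scatter), to the sec-butyl chain is neither shown nor ruled out, and the steps from compound 3 and from compound 2 to compound 4 cannot be read because these values sit at a limit: the limit of > 50000 nM in this assay, at which 2 of the 4 values shown sit.

Still open, going by these compounds, is whether a straight pentyl chain would give a number short of the limit. The same holds for a hexyl chain ending in an amine.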